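A few compounds are considered here, and "the series" means these few. Any claim that something is new, unique, unknown or untested is made for them only; others in the source may bear on it.

Compound 1 `CC1(C)CCc2cc(C(=O)/C=C/c3ccc(OCc4cn(Cc5ccc([N+](=O)[O-])cc5)nn4)cc3)c(O)cc2O1` and compound 2 `CCCCCn1cc(COc2ccc(/C=C/C(=O)c3cc4c(cc3O)OC(C)(C)CC4)cc2)nn1` share one core and differ in a single place: butyl in place of 4-nitrophenyl on a saturated chain carbon bound to an aromatic nitrogen. In a functional assay on A549 cells (Homo sapiens) for antiproliferative activity, read by MTT assay (on this read-out lower numbers stand for stronger inhibition and higher numbers for weaker inhibition), compound 1 gives 35800 nM, and compound 2 gives 91300 nM, so the change made a 2.6-fold higher number from compound 1 to compound 2 (0.41 log units; beyond the scatter). Compound 3 `CC1(C)CCc2c(ccc(C(=O)/C=C/c3ccc(OCc4cn(Cc5ccc([N+](=O)[O-])cc5)nn4)cc3)c2O)O1` is built from the same atoms as compound 1, joined differently; the difference between the two cores is not broken down here. In this assay compound 3 gives 69900 nM, a number that sits within the usual scatter of both compound 2 and compound 1. Compound 4 `CCCCCn1cc(COc2ccc(/C=C/C(=O)c3ccc4c(c3O)CCC(C)(C)O4)cc2)nn1` has not yet been measured. It differs from compound 3 by the same change seen between compound 1 and compound 2, at the same place: butyl in place of 4-nitrophenyl on a saturated chain carbon bound to an aromatic nitrogen. Within the data shown here, because the one measured example gave a 2.6-fold higher number from compound 1 to compound 2 (0.41 log units; beyond the scatter), a step of roughly that size is expected here, a 2.3-fold higher number from compound 3 to compound 4 (0.36 log units; beyond the scatter), though a single example on a differently joined core keeps the expectation loose. Compound 4 is therefore estimated at 160000 nM in this assay, most likely between 70000 nM and 400000 nM.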

Compound 4, half-maximal inhibitory concentration: 48600 nM
Compound 4: the middle estimate sits 3.3-fold (0.52 log units) above what was measured; the measured number lies below the stated range.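

In this assay, putting butyl in place of 4-nitrophenyl does not have the same outcome on the two cores: the same change on two cores in this assay, a 2.6-fold higher number (0.41 log units; beyond the scatter) from compound 1 to compound 2 and a 1.4-fold lower number (0.16 log units; within the scatter) from compound 3 to compound 4, 3.7-fold (0.56 log units) apart, beyond the scatter of two such steps On the core of compound 3 the swap gives a 1.4-fold lower number from compound 3 to compound 4 (0.16 log units; within the scatter), so compound 3 and compound 4 cannot be told apart in this assay, whereas on the core of compound 1 the same swap gives a step beyond the scatter. Among these compounds, this means that the step measured on one core was a poor guide to the step on the other, but with only one pair per core it does not show why the two cores part ways, or whether other changes at this place would also depend on the core.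

The compounds shown leave open whether a longer chain, or a chain ending in an amine or a carboxylic acid, would also behave differently on the two cores. They also leave open how a plain benzyl group, without the nitro group, would compare on each core.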